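The compounds below may be only part of what the source reports. "The series", "measured", "known", "first", "only" and "open" are said of these compounds alone.

Working notes on the series. Compound 1 `COc1ccc(S(=O)(=O)c2cnc3ccc(F)cc3c2N2CCC(C)CC2)cc1` gives 85% in an assay on isolated protein for displacement of a labelled ligand from metabotropic glutamate receptor 5 (Homo sapiens), with a stated time of 60 min, tested at 1 uM; on this read-out lower numbers stand for less inhibition and higher numbers for more inhibition at the one concentration tested (going by the name of the read-out). Compound 2 `CC1CCN(c2c(S(=O)(=O)c3cccc(Cl)c3)cnc3ccc(Cl)cc23)CC1` gives 92% in this assay. Compound 3 `CC1CCN(c2c(S(=O)(=O)c3cccc(C#N)c3)cnc3ccc(F)cc23)CC1` gives 93% in this assay; this is the largest of the three numbers, yet the gaps to compound 2 and to compound 1 both lie within the scatter, so no order among the three is claimed. Among the compounds with values here, the one single-point step measured so far, a number 8 percentage points higher from compound 1 to compound 3 (within the scatter), also runs within the scatter.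

Compound 4 `CC1CCN(c2c(S(=O)(=O)c3cccc(Cl)c3)cnc3ccc(F)cc23)CC1` differs from compound 3 by chloro in place of cyano on an aromatic carbon. Within the data shown here, no measured step exchanges these two groups directly. Compound 2 carries the same 3-chlorophenyl on the sulfonyl sulfur, with a different group on the shared core, and its value and that of compound 3 sit within the scatter of each other. Among the measured compounds shown here, the only step with the sulfonyl aryl group changed, a number 8 percentage points higher from compound 1 to compound 3 (within the scatter), stayed within the scatter. A step of no more than the scatter is therefore expected for compound 4, a number 3 percentage points lower from compound 3 to compound 4 (within the scatter). Compound 4 is estimated at 90%, in the range 82% to 96%.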

Compound 4, a percentage reported as inhibition, at one concentration (the size of the read-out at that concentration, not a potency): 92%
For compound 4 the middle estimate is 2 percentage points below the measured one; measured number inside the range.
By their numbers in this assay, from the lowest: compounds 1, 2, 4 and 3 (each within the scatter of the next).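

Chloro in place of cyano on this aromatic carbon, the first direct exchange of these two groups, gives a number 1 percentage points lower from compound 3 to compound 4 (within the scatter) in this assay and so leaves the read-out unresolved between them. For 3-chlorophenyl in place of 4-methoxyphenyl, the result of a number 7 percentage points higher from compound 1 to compound 4 (within the scatter) adds a second change of the sulfonyl aryl group that stays inside the scatter. Fluoro in place of chloro on the shared core gives no change at the digits printed from compound 2 to compound 4 (within the scatter) and is the first step shown at that place, so at the one concentration tested neither place separates these compounds.

Going by these compounds, whether a carboxylic acid or an aminomethyl group on this aromatic carbon would move the number beyond the scatter stays open. Nothing on hand bears on why these steps are this small.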